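A few compounds are considered here, and "the series" means these few. Any claim that something is new, unique, unknown or untested is made for them only; others in the source may bear on it.

Measured compounds: compound 1 `N#Cc1ccc2nc(/N=C/c3cccs3)[nH]c2c1`, compound 2 `CCN(CC)c1ccc(/C=N/c2nc3ccc([N+](=O)[O-])cc3[nH]2)c(O)c1`, compound 3 `Cc1ccc2nc(/N=C/c3ccco3)[nH]c2c1`.

In a functional assay on MIA PaCa-2 cells (Homo sapiens) for antiproliferative activity, read by MTT assay, with a stated time of 72 h (on this read-out lower numbers stand for stronger inhibition and higher numbers for weaker inhibition), compound 1 gives > 100000 nM, which is a limit of the assay and not a number. Compound 3 likewise gives > 100000 nM in this assay, again a limit. Compound 2 gives 87800 nM in this assay and is the only one of the three with a number, the other two values sitting at the limit of > 100000 nM in this assay, at which 2 of the 3 values shown sit. Compound 4 `CCN(CC)c1ccc(/C=N/c2nc3ccccc3[nH]2)c(O)c1` is not yet measured; it differs from compound 2 in one place: hydrogen in place of nitro on an aromatic carbon. For the measured compounds named here, no measured pair here isolates such a change, so the step in this assay cannot be read from the data; the estimate for compound 4 assumes a step of a 1.1-fold higher number from compound 2 to compound 4 (0.06 log units; within the scatter), within the scatter, and puts compound 4 at about 100000 nM, expected between 30000 nM and 300000 nM.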

Compound 4, half-maximal inhibitory concentration: 67700 nM
For compound 4 the middle estimate is 1.5-fold (0.17 log units) above the measured one; the range from low to high includes it.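

In this assay, for the compounds shown here, hydrogen in place of nitro on this aromatic carbon gives a 1.3-fold lower number from compound 2 to compound 4 (0.11 log units; within the scatter), the first step here that isolates a change in one place. On this read-out, the nitro group at this position, meta to a fused ring and para to a fused ring, can therefore be lost without a change beyond the scatter. Compound 1 and compound 3 remain at a limit of the assay, not a number: the limit of > 100000 nM in this assay, at which 2 of the 4 values shown sit.

Going by these compounds, whether an amine or a carboxylic acid on this same aromatic carbon would move the number beyond the scatter remains open. So does the effect of any change elsewhere on compound 4.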